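Working notes: side-chain amine variation in one series

The source may report more compounds than this note shows. Statements on the series, on what has been measured and on what is new or still open speak of the compounds shown alone.

Measured so far:
Compound 1, `CCN1CCCC[C@H]1[C@H]1COC(c2ccccc2)(c2ccccc2)O1`: 6900 nM
Compound 2, `C[C@H](N)[C@H]1COC(c2ccccc2)(c2ccccc2)O1`: 607 nM

Among the compounds with values here, in a functional assay (brain) for displacement of a labelled ligand, with Rattus norvegicus as the target (on this read-out higher numbers stand for weaker inhibition and lower numbers for stronger inhibition), compound 2 has the lowest of the two numbers so far. Within the data shown here, the one step measured is an 11-fold lower number from compound 1 to compound 2 (1.06 log units; beyond the scatter).

Compound 3, `CNC[C@H]1COC(c2ccccc2)(c2ccccc2)O1`, differs from compound 2 in this way: (methylamino)methyl in place of 1-aminoethyl on a saturated ring carbon. Among the measured compounds shown here, the single measured step bears on this only loosely, since it exchanged a ring-bearing group for a chain, whereas compound 3 merely rearranges the same atoms of the chain. No step beyond the scatter is therefore expected, the estimated change being a 1.2-fold lower number from compound 2 to compound 3 (0.08 log units; within the scatter). Compound 3 is estimated at 500 nM, with a range from 150 nM to 1700 nM.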

Compound 3, inhibition constant: 7300 nM
Compound 3: middle estimate off by 15-fold (1.16 log units), on the low side, and the stated range ends below it.
By their numbers in this assay, from the lowest: compound 2; then compounds 1 and 3 (each within the scatter of the next).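

In this assay, rearranging the same atoms within the side chain is far from neutral: (methylamino)methyl in place of 1-aminoethyl gives a 12-fold higher number from compound 2 to compound 3 (1.08 log units; beyond the scatter). In place of 1-ethylpiperidin-2-yl, (methylamino)methyl gives a 1.1-fold higher number from compound 1 to compound 3 (0.02 log units; within the scatter), which leaves compound 2 alone apart from the other two. No measurement at hand explains this difference.

Still open, going by these compounds, is whether the lower number of compound 2 goes with its unsubstituted amine, its branching methyl or its defined stereocentre, since these change together here. Aminomethyl and 1-(methylamino)ethyl groups on the same ring carbon would bear on this.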